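Quinoline Sulfones: Predicting Clearance for a Fluorophenyl Analogue

The source may report more compounds than this note shows. Statements on the series, on what has been measured and on what is new or still open speak of the compounds shown alone.

Compound 1 `O=S(=O)(c1ccc(F)c(Cl)c1)c1cnc2c(F)cccc2c1-c1cccc(Cl)c1`: 0.18 mL/min
Compound 2 `O=S(=O)(c1ccc(F)c(F)c1)c1cnc2c(F)cccc2c1-c1ccc(Cl)cc1`: 0.28 mL/min
Compound 3 `COc1cccc(-c2c(S(=O)(=O)c3ccc(C)c(F)c3)cnc3c(F)cccc23)c1`: 4.02 mL/min

Three compounds sharing one core were examined in an ADME assay on microsomes from liver (Homo sapiens) for metabolic stability, tested at 2.5 uM; on this read-out higher numbers stand for fast clearance and lower numbers for slow clearance. Compound 1 gives the lowest of the three numbers, with 0.18 mL/min; compound 2 stands nearest to it at 0.28 mL/min, a gap that lies within the scatter, while compound 3, at 4.02 mL/min, lies far beyond it. The unmeasured compound 4 `O=S(=O)(c1ccc(F)c(Cl)c1)c1cnc2c(F)cccc2c1-c1ccccc1F` differs from compound 1 at one place: 2-fluorophenyl in place of 3-chlorophenyl on an aromatic carbon. Within the data shown here, with the sulfonyl part and the core unchanged, and no comparable step among the measured compounds to lean on, the expectation for this assay is a small step from compound 1 to compound 4, if any, likely within the scatter, and compound 4 is estimated at 0.25 mL/min (range 0.1 mL/min to 0.65 mL/min), corresponding to an expected 1.4-fold higher number from compound 1 to compound 4 (0.14 log units; within the scatter).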

Compound 4, intrinsic clearance in a liver preparation (reported as CLH), per the amount of preparation that the assay uses: 1.39 mL/min
Estimate against measurement, compound 4: 5.6-fold (0.75 log units) below; the measured number lies above the stated range.
By their numbers in this assay, from the lowest: compounds 1 and 2 (each within the scatter of the next); then compound 4; then compound 3.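

In this assay, the group on this aromatic carbon proves to matter: with the sulfonyl part and the core unchanged, 2-fluorophenyl in place of 3-chlorophenyl gives a 7.7-fold higher number from compound 1 to compound 4 (0.89 log units; beyond the scatter), a step beyond the scatter. Among these compounds, the earlier compounds offered no single-place step, so this is the first reading of this position on its own. Nothing shown accounts for the step.

This one step changes the halogen and its place on the phenyl ring together, and the two cannot be told apart. As far as these compounds go, how a phenyl ring carrying an amine or a carboxylic acid would read at this position also remains open.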